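Thioether chain isomers of a prostacyclin-like series

The compounds below may be only part of what the source reports. "The series", "measured", "known", "first", "only" and "open" are said of these compounds alone.

Among the compounds with values here, compound 2 `CCCCC[C@H](O)/C=C/[C@H]1[C@H](O)CC(=O)[C@@H]1CSCCCCC(=O)O` gives 1400 nM in an assay on CHO cells for binding affinity to prostacyclin receptor (Homo sapiens) (on this read-out higher numbers stand for weaker inhibition and lower numbers for stronger inhibition), and is the only numerical value in the set. Compound 1 `COCc1cccc(C[C@H](O)/C=C/[C@H]2[C@H](O)CC(=O)[C@@H]2CCSCCCC(=O)O)c1` returns only a limit in this assay, > 10000 nM, so the limit of > 10000 nM in this assay, at which 1 of the 2 values shown sits, marks where it sits. Compound 3 `CCCCC[C@H](O)/C=C/[C@H]1[C@H](O)CC(=O)[C@@H]1CCSCCCC(=O)O` is not yet measured; it differs from compound 2 only in that (((3-carboxypropyl)sulfanyl)methyl in place of (4-carboxybutyl)sulfanyl on a saturated chain carbon bound to a saturated ring carbon). Within the data shown here, no measured step of this kind exists, so the expected step is a moderate loss, a 2.9-fold higher number from compound 2 to compound 3 (0.46 log units; beyond the scatter), beyond the usual scatter. Compound 3 is therefore estimated at 4000 nM, with a range from 1200 nM to 15000 nM.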

Compound 3, inhibition constant: 750 nM
Beside the measured number, compound 3's estimate is 5.3-fold (0.73 log units) above it; measured number below the stated range.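

In this assay, ((3-carboxypropyl)sulfanyl)methyl in place of (4-carboxybutyl)sulfanyl gives a 1.9-fold lower number from compound 2 to compound 3 (0.27 log units; within the scatter), so this pair of chain isomers is not separated at this position. Butyl in place of 3-(methoxymethyl)phenyl gives an at least 13-fold lower number from compound 1 to compound 3 (1.12 log units; beyond the scatter), the first step in the series beyond the scatter. Compound 1 carries a limit, not a number: the limit of > 10000 nM in this assay, at which 1 of the 3 values shown sits.

Still open, from the compounds shown here alone, is how a plain phenyl or a cyclohexyl would read in place of the butyl. Also open, going by these compounds, is whether an oxygen in place of the chain sulfur, or a longer chain, would hold the reading of compound 3.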